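The compounds below may be only part of what the source reports. "The series", "measured", "known", "first", "only" and "open" are said of these compounds alone.

Compound 1 `O=CNc1ccc(C2=NNC(=O)CC2)cc1` is the parent of this small set. In a functional assay for inhibition, with Homo sapiens as the target (on this read-out higher numbers stand for an effect only at larger amounts of compound and lower numbers for an effect already at smaller amounts), compound 1 gives 3.74 ug/mL, which places it second highest of the three numbers recorded. Compound 2 `O=C1CCC(c2ccc(NC(=O)CCl)cc2)=NN1` gives 0.39 ug/mL in this assay, and the step of a 9.6-fold lower number from compound 1 to compound 2 (0.98 log units; beyond the scatter). Compound 3 `CCCNCC(=O)Nc1ccc(C2=NNC(=O)CC2)cc1` gives about 46.4 ug/mL in this assay, and the step of a 12-fold higher number from compound 1 to compound 3 (1.09 log units; beyond the scatter). Between compound 2 and compound 3 the step of a 120-fold higher number from compound 2 to compound 3 (2.08 log units; beyond the scatter).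

Compound 4 `CC(C)NCC(=O)Nc1ccc(C2=NNC(=O)CC2)cc1` has not yet been measured. It differs from compound 1 in one place: (isopropylamino)methyl in place of hydrogen on a carbonyl carbon. The step bearing most directly on this change is a 12-fold higher number from compound 1 to compound 3 (1.09 log units; beyond the scatter), where a (propylamino)methyl group likewise replaced hydrogen on a carbonyl carbon, and the step of a 120-fold higher number from compound 2 to compound 3 (2.08 log units; beyond the scatter) points in the same direction. Compound 4 is therefore expected to move the same way, by an 11-fold higher number from compound 1 to compound 4 (1.03 log units; beyond the scatter). In this assay compound 4 is estimated at 40 ug/mL, with a range from 12 ug/mL to 130 ug/mL.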

Compound 4, half-maximal effective concentration: about 46.4 ug/mL
Estimate against measurement, compound 4: 1.2-fold (0.06 log units) below; low and high end bracket the measured number.
By their numbers in this assay, from the lowest: compound 2; then compound 1; then compounds 3 and 4 (each within the scatter of the next).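

In this assay, isopropyl in place of propyl on the amine nitrogen leaves no readable difference, with no change at the digits printed from compound 3 to compound 4 (within the scatter). The large rise from the parent formyl compound therefore does not depend on the propyl group being straight: the step is a 12-fold higher number from compound 1 to compound 4 (1.09 log units; beyond the scatter), the same size at the digits printed as the step to the propyl compound. The gap to the chloromethyl compound is equally preserved, at a 120-fold higher number from compound 2 to compound 4 (2.08 log units; beyond the scatter), so both amines shown sit far from it at this position.

From the compounds shown here alone, whether a methylamino group, a piperidine ring or a longer chain on the nitrogen would stay at this level remains open. Nothing among the data shown accounts for the size of these steps.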